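Thiazole substituent series: trifluoromethyl step

A few compounds are considered here, and "the series" means these few. Any claim that something is new, unique, unknown or untested is made for them only; others in the source may bear on it.

Measured compounds in a functional assay on CHO-K1 cells for antagonist activity at C-X-C chemokine receptor type 3 (Homo sapiens), read by FLIPR, with a stated time of 10 min; on this read-out higher numbers stand for weaker inhibition and lower numbers for stronger inhibition:
compound 1 `O=C(Cn1cnc2cccnc21)N1CCN(c2scnc2-c2nc3ccccc3[nH]2)CC1` gives 30 nM;
compound 2 `Cc1nc(-c2nc3ccccc3[nH]2)c(N2CCN(C(=O)Cn3cnc4cccnc43)[C@H](C)C2)s1` gives 9 nM;
compound 3 `C[C@@H]1CN(c2sc(C3CC3)nc2-c2nc3ccccc3[nH]2)CCN1C(=O)Cn1cnc2cccnc21` gives 9.7 nM.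

Compound 3 stands second highest of the three numbers in this assay. Its nearest neighbour is compound 2, and the two differ only by the step of a 1.1-fold higher number from compound 2 to compound 3 (0.03 log units; within the scatter), so nothing separates them here. Compound 1, which lacks both the methyl on the piperazine and any group on the thiazole carbon, gives a number that lies beyond the scatter above compound 3.

Compound 4 `C[C@@H]1CN(c2sc(C(F)(F)F)nc2-c2nc3ccccc3[nH]2)CCN1C(=O)Cn1cnc2cccnc21` differs from compound 3 in one place: trifluoromethyl in place of cyclopropyl on an aromatic carbon. Among the compounds with values here, the only measured step at this position, from compound 2 to compound 3, did not move the number beyond the scatter; no measured step involves trifluoromethyl, so that step is the sole guide. On that basis a step in this assay from compound 3 to compound 4 of about a 1.2-fold higher number from compound 3 to compound 4 (0.09 log units; within the scatter) is expected, staying within the scatter. Compound 4 is therefore estimated at 12 nM, with a range from 5 nM to 30 nM.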

Compound 4, half-maximal inhibitory concentration: 1.6 nM
For compound 4 the middle estimate is 7.5-fold (0.88 log units) above the measured one, outside the stated range (below it).
By their numbers in this assay, from the lowest: compound 4; then compounds 2 and 3 (each within the scatter of the next); then compound 1.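

In this assay the aromatic carbon next to the ring nitrogen and next to the ring sulfur proves sensitive to its substituent: trifluoromethyl in place of cyclopropyl gives a 6.1-fold lower number from compound 3 to compound 4 (0.78 log units; beyond the scatter) and trifluoromethyl in place of methyl gives a 5.6-fold lower number from compound 2 to compound 4 (0.75 log units; beyond the scatter) whereas cyclopropyl in place of methyl gave only a 1.1-fold higher number from compound 2 to compound 3 (0.03 log units; within the scatter) at the same carbon. The flat response between methyl and cyclopropyl therefore does not extend to trifluoromethyl, the only one of the three whose steps lie beyond the scatter. Nothing available accounts for this difference.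

The compounds shown leave open whether other groups on this carbon, such as chlorine, a nitrile or a methoxy group, track trifluoromethyl or stay with methyl and cyclopropyl. They also leave open whether trifluoromethyl here would act the same way on the core of compound 1.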